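Methyl for chloro on the core of compound 1

The source may report more compounds than this note shows. Statements on the series, on what has been measured and on what is new or still open speak of the compounds shown alone.

Working notes on the series. Compound 1 `Cc1cc(C)nc(SCc2cc(=O)c3cc(Cl)ccc3o2)n1` is the reference point here. In a functional assay on HEp-2 cells (Homo sapiens) for cytotoxicity, read by MTT assay, with a stated time of 72 h (a lower number here means a stronger inhibitor, a higher number a weaker inhibitor), compound 1 gives > 25000 nM, which is a limit of the assay and not a measured number. Compound 1 therefore stands only at the edge of what this assay resolves; of the two values in hand, one sits at that edge (the limit of > 25000 nM in this assay, at which 1 of the 2 values shown sits). Compound 2 `Cc1nnc(SCc2coc3ccc(Cl)cc3c2=O)s1` is the other measured member of the set, built on a different arrangement of the same pieces. In this assay compound 2 gives 4200 nM. Among the compounds with values here, no pair of measured compounds differs in a single place, so no measured step is available to calibrate the change at hand.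

Compound 3 `Cc1ccc2oc(CSc3nc(C)cc(C)n3)cc(=O)c2c1` is the next candidate for this assay. It differs from compound 1 by methyl in place of chloro on an aromatic carbon. With compound 1 at a limit, the expected step that the limit leaves unreadable from compound 1 to compound 3 is taken to be no more than the usual scatter, with no clear direction. Compound 3 is accordingly expected to give 30000 nM, with a range from 8000 nM to 100000 nM, and quite possibly to be reported again only as a limit.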

Compound 3, half-maximal inhibitory concentration: > 25000 nM
Compound 3: no number, only a limit; the forecaster's own chance of this, stated with the estimate: 65%; the middle value does not contradict the limit.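

In this assay compound 3 gives > 25000 nM, which is a limit and not a number. Compound 1 also stands at a limit, so no step can be read between compound 1 and compound 3: the limit of > 25000 nM in this assay, at which 2 of the 3 values shown sit.

The compounds shown leave open whether methyl in place of chloro on an aromatic carbon changes the result in this assay at all.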